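Swapping Nitrophenyl for Methoxyphenyl in Two Inactive Analogues

The compounds below may be only part of what the source reports. "The series", "measured", "known", "first", "only" and "open" are said of these compounds alone.

Compound 1 `CC1(C)Cc2c(OCc3ccccc3)ccc(C(=O)/C=C/c3cn(-c4ccccc4)nc3-c3ccc([N+](=O)[O-])cc3)c2O1` and compound 2 `CC1(C)Cc2c(ccc(C(=O)/C=C/c3cn(-c4ccccc4)nc3-c3cccc([N+](=O)[O-])c3)c2OCc2ccccc2)O1` share one core and differ only in their nitrophenyl group. In a functional assay on HT-29 cells (Homo sapiens) for antiproliferative activity, read by MTT assay, with a stated time of 48 h (a higher number here means a weaker inhibitor, a lower number a stronger inhibitor), compound 1 gives > 100000 nM, which is a limit of the assay rather than a number. Compound 2 likewise reaches only a limit in this assay, > 100000 nM. Compound 2 thus stands at the top edge of what the assay reports, where the limit of > 100000 nM in this assay, at which 2 of the 2 values shown sit, places every value shown. Compound 3 `COc1ccc(-c2nn(-c3ccccc3)cc2/C=C/C(=O)c2ccc3c(c2OCc2ccccc2)CC(C)(C)O3)cc1` carries 4-methoxyphenyl in place of 3-nitrophenyl on an aromatic carbon. No measured step joins any two of these compounds, so the size of such a change has no precedent here. With both neighbours at the limit, compound 3 is expected to stay close to it, estimated at 100000 nM with a range from 30000 nM to 300000 nM. The expected step of a number no higher from compound 2 to compound 3 (the limit leaves the size open) amounts to no change beyond the scatter.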

Compound 3, half-maximal inhibitory concentration: > 100000 nM
Compound 3: a limit, no number; the forecaster's own chance of this, stated with the estimate: 65%; the middle value sits exactly at the limit.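

For the compounds shown here, compound 3 reaches only a limit in this assay, > 100000 nM, so no step between compound 2 and compound 3 can be read, nor any other new step. The compounds shown leave open whether any group at this place on the shared core gives a measurable value in this assay.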